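Replacing the group on the amide nitrogen of compound 3

The source may hold more compounds than are shown below. What is called first, only, known or untested is meant among the compounds shown, and "the series" means these compounds.

Values measured in a physicochemical assay for lipophilicity, at pH 7.4; on this read-out lower numbers stand for lower lipophilicity and higher numbers for higher lipophilicity:
Compound 1 `O=C(Nc1cnc2[nH]ncc2c1)[C@H]1CCCN1C(=O)C1(c2cccc(Cl)c2)CCCC1`: 4.9
Compound 2 `O=C(Nc1ccc2[nH]ncc2c1)[C@H]1CCCN1C(=O)C1(c2cccc(Cl)c2)CCCC1`: 5.4
Compound 3 `O=C(Nc1ccc2[nH]nnc2c1)[C@H]1CCCN1C(=O)C1(c2cccc(Cl)c2)CCCC1`: 5.2

Compound 3 stands within the scatter of both other compounds, as shown by a number 0.30 log units higher from compound 1 to compound 3 (within the scatter) and by a number 0.20 log units lower from compound 2 to compound 3 (within the scatter). Compound 4 `CNC(=O)c1ccc(NC(=O)[C@H]2CCCN2C(=O)C2(c3cccc(Cl)c3)CCCC2)cc1` has not yet been measured. It carries 4-(methylcarbamoyl)phenyl in place of the group held by compound 3, on an amide-type nitrogen: a group of 10 heavy atoms (8 carbon, 1 nitrogen, 1 oxygen; one six-membered aromatic ring of carbon only) in place of a group of 9 heavy atoms (6 carbon, 3 nitrogen; one five-membered aromatic ring with 3 hetero atoms, one six-membered aromatic ring of carbon only), on an amide-type nitrogen.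

All three measured steps changed the group at this same place, and only one went beyond the scatter: a number 0.50 log units higher from compound 1 to compound 2 (beyond the scatter). None of them brought in 4-(methylcarbamoyl)phenyl, so the data hold no direct measure of this change, and the direction expected here is a judgement from the structural change alone. In this assay, a step of similar size to that one is expected, namely a number 0.40 log units lower from compound 3 to compound 4 (beyond the scatter). For compound 4 the estimated value is 4.8, with an expected range from 4.3 to 5.3.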

Compound 4, distribution coefficient: 5.3
For compound 4 the middle estimate is 0.50 log units below the measured one; low and high end bracket the measured number.
By their numbers in this assay, from the lowest: compounds 1, 3, 4 and 2 (each within the scatter of the next, the first and the last beyond it).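

In this assay, 4-(methylcarbamoyl)phenyl, with one six-membered aromatic ring of carbon only, gives no step beyond the scatter from either group whose six-membered aromatic ring is of carbon only and carries a five-membered aromatic ring as well: a number 0.10 log units higher from compound 3 to compound 4 (within the scatter), and a number 0.10 log units lower from compound 2 to compound 4 (within the scatter). Going by these compounds alone, only one new step passes the scatter, a number 0.40 log units higher from compound 1 to compound 4 (beyond the scatter), so at this place on the amide-type nitrogen, the five-membered aromatic ring is not needed for a read-out in this range. No measurement at hand explains these steps.

The compounds shown leave open how the read-out responds when a carboxylic acid or an amine stands in place of the methylcarbamoyl group of compound 4. They also leave open whether a longer chain on that amide nitrogen would keep the value of compound 4 at 5.3.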